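Taking the nitro group off compound 2

This account rests on a few compounds, and the source may have more. Where it says the series, first, only, none or still open, it means among the compounds named here.

In a functional assay on MOLT-4 cells (Homo sapiens) for inhibition, read by MTT assay, with a stated time of 48 h (a higher number here means a weaker inhibitor, a lower number a stronger inhibitor), compound 1 `CN(C)c1ccc(/C=C/C(=O)c2ccco2)cc1` gives 12000 nM and compound 2 `O=C(/C=C/c1cccc([N+](=O)[O-])c1)c1ccco1` gives 18000 nM with the two values within the scatter of each other. Compound 3 `O=C(/C=C/c1ccccc1)c1ccco1` differs from compound 2 by hydrogen in place of nitro on an aromatic carbon with hydrogen in place of nitro on an aromatic carbon. Among the measured compounds shown here, no measured pair isolates this change, so the expectation in this assay rests only on compound 2 at 18000 nM and no shift beyond the scatter is foreseen in either direction. The expected size is a 1.2-fold lower number from compound 2 to compound 3 (0.08 log units; within the scatter) and no direction is favoured. For compound 3 the estimated value is 15000 nM with an expected range from 7000 nM to 35000 nM in this working estimate.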

Compound 3, half-maximal inhibitory concentration: > 100000 nM
Compound 3: no number, only a limit (the forecaster's own chance of this, stated with the estimate: 10%); at least 6.6-fold (0.82 log units) between middle value and limit.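

In this assay compound 3 gives > 100000 nM, which is a limit and not a number. Hydrogen in place of nitro gives an at least 5.5-fold higher number from compound 2 to compound 3 (0.74 log units; beyond the scatter), and hydrogen in place of dimethylamino gives an at least 8.3-fold higher number from compound 1 to compound 3 (0.92 log units; beyond the scatter), so in this small set a group on the six-membered aromatic ring goes with a measurable value and hydrogen does not. The true size of both steps stays unknown, because compound 3 reads only as a limit: the limit of > 100000 nM in this assay, at which 1 of the 3 values shown sits.

The compounds shown leave open whether a methyl or an amine on the same aromatic carbon would serve as nitro does.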